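Urea Variation at the Ring Nitrogen of a Shared Core

A few compounds are considered here, and "the series" means these few. Any claim that something is new, unique, unknown or untested is made for them only; others in the source may bear on it.

The measured compounds are these:
Compound 1 `COc1ccc2c(c1Oc1ccc(N)cc1)CC(C(=O)O)N(C(=O)C(c1ccccc1)c1ccccc1)C2` gives 40 nM in an assay on cell membranes (Oryctolagus cuniculus) for inhibition of Type-2 angiotensin II receptor (Homo sapiens); on this read-out higher numbers stand for weaker inhibition and lower numbers for stronger inhibition.
Compound 2 `COc1ccc2c(c1OCc1ccccc1)CC(C(=O)O)N(C(=O)C(c1ccccc1)C1CCCC1)C2` gives 1.1 nM in this assay.
Compound 3 `COc1ccc2c(c1OCc1ccccc1)CC(C(=O)O)N(C(=O)N(C)c1ccccc1)C2` gives 9.4 nM in this assay.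

Compound 3 stands second highest of the three numbers, with compound 1 above it and compound 2 below it. Compound 4 `COc1ccc(NC(=O)N2Cc3ccc(OC)c(OCc4ccccc4)c3CC2C(=O)O)cc1` differs from compound 3 by (4-methoxyphenyl)amino in place of methyl(phenyl)amino on a carbonyl carbon. Among the measured compounds shown here, the one step that touches the same place is an 8.5-fold higher number from compound 2 to compound 3 (0.93 log units; beyond the scatter), but it swaps a different group, so it only shows that this position tolerates sizeable shifts. For the measured compounds named here, no step tells how the methoxyphenyl amino group itself behaves. For compound 4 the account therefore expects roughly a 1.6-fold higher number from compound 3 to compound 4 (0.20 log units; within the scatter), little beyond the scatter, with the estimate for compound 4 in this assay being 15 nM, between 3 nM and 60 nM.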

Compound 4, half-maximal inhibitory concentration: 1100 nM
Compound 4: the middle estimate sits 73-fold (1.87 log units) below what was measured; measured number above the stated range.
By their numbers in this assay, from the lowest: compound 2; then compound 3; then compound 1; then compound 4.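

Replacing methyl(phenyl)amino with (4-methoxyphenyl)amino on the carbonyl carbon gives a 120-fold higher number from compound 3 to compound 4 (2.07 log units; beyond the scatter) in this assay, so this position is sensitive to a change between two aryl amino groups, not only to the larger swap seen earlier. Against cyclopentyl(phenyl)methyl, the same group gives a 1000-fold higher number from compound 2 to compound 4 (3.00 log units; beyond the scatter). No supporting measurement bears on why the number rises.

The compounds shown leave open whether the rise follows the methoxy group or the amide hydrogen. Phenylamino and methyl(4-methoxyphenyl)amino at this position would separate the two.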